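Changing a terminal ring substituent on a sulfonamide benzoic acid

The compounds below may be only part of what the source reports. "The series", "measured", "known", "first", "only" and "open" are said of these compounds alone.

Measured compounds:
compound 1, `CCCCCCCCS(=O)(=O)Nc1cc(-c2ccc(CCCC)cc2)ccc1C(=O)O`, 15700 nM
compound 2, `CCCCCCCCS(=O)(=O)Nc1cc(-c2ccccc2-c2ccccc2)ccc1C(=O)O`, 17100 nM

Two compounds share a core carrying an octylsulfonamide and a carboxylic acid, and differ only in the group on the outer ring. In an assay on mitochondria (strain BALB/c) for inhibition of glycerol-3-phosphate acyltransferase 1, mitochondrial (Mus musculus), read by scintillation counting, with a stated time of 10 min (on this read-out lower numbers stand for stronger inhibition and higher numbers for weaker inhibition), compound 1 gives 15700 nM. In the same assay compound 2 gives 17100 nM, which is the higher of the two numbers, but the gap to compound 1 lies within the usual scatter, so the two compounds cannot be told apart on these data.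

Compound 3, `CCCCCCCCS(=O)(=O)Nc1cc(-c2ccccc2OC)ccc1C(=O)O`, has not yet been measured in this assay. It differs from compound 2 by methoxy in place of phenyl on an aromatic carbon. Going by the values given here, no step between measured compounds describes this kind of change, so there is nothing in the data that points firmly in either direction. Because compound 2 gives 17100 nM and compound 1 sits close to it, the expectation is that compound 3 will land near the same level, with a possible drift to a somewhat higher number; the expected step is a 1.4-fold higher number from compound 2 to compound 3 (0.15 log units; within the scatter). Compound 3 is estimated at 24000 nM, within a range of 8000 nM to 75000 nM.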

Compound 3, half-maximal inhibitory concentration: 16100 nM
Compound 3: middle estimate off by 1.5-fold (0.17 log units), on the high side, within the range that was stated.
By their numbers in this assay, from the lowest: compounds 1, 3 and 2 (each within the scatter of the next).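

In this assay the exchange of phenyl for methoxy, on an aromatic carbon ortho to a large group, takes away a whole six-membered aromatic ring and brings in a hydrogen-bond acceptor, yet it amounts only to a 1.1-fold lower number from compound 2 to compound 3 (0.03 log units; within the scatter) and so stays inside the usual scatter. The exchange of 4-butylphenyl for 2-methoxyphenyl, which alters the outer ring in a different way, comes to a 1.0-fold higher number from compound 1 to compound 3 (0.01 log units; within the scatter) and likewise cannot be told from no difference, so compound 1, compound 2 and compound 3 form one level on this read-out despite the large differences among their groups. Nothing on hand explains why these groups give the same level.

Still open, from the compounds shown here alone, is whether any group at this position can shift the number beyond the scatter, for instance an amine, a hydroxyl or a carboxylic acid in place of the methoxy. Also open, going by these compounds, is what a shorter chain in place of the octyl group, or an amide in place of the carboxylic acid on the shared core, would do to the number.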